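The source may hold more compounds than are shown below. What is called first, only, known or untested is meant among the compounds shown, and "the series" means these compounds.

Compound 1 `CC(=O)c1cc(C(=O)N[C@@H](C)Cn2ccc(-c3cc(F)c(C#N)c(Cl)c3)n2)n[nH]1`: 1100 nM
Compound 2 `C[C@@H](Cn1ccc(-c2ccc(C#N)c(Cl)c2)n1)NC(=O)c1ccccc1`: 1830 nM
Compound 3 `C[C@@H](Cn1ccc(-c2ccc(C#N)c(Cl)c2)n1)NC(=O)c1cccc(OCC(O)CO)c1`: 740 nM

All three were measured in a functional assay on LNCaP cells (Homo sapiens) for antiproliferative activity, read by CCK-8 assay, with a stated time of 6 days; a lower number here means a stronger inhibitor, a higher number a weaker inhibitor. Compound 2 gives the highest number of the three; compound 1 sits within the scatter of it, while compound 3 lies beyond. For the measured compounds named here, the only step in the set, a 2.5-fold lower number from compound 2 to compound 3 (0.39 log units; beyond the scatter), concerns a group added on an aromatic carbon while the benzoyl itself stays, so it does not test the exchange that follows. Compound 4 `C[C@@H](Cn1ccc(-c2ccc(C#N)c(Cl)c2)n1)Nc1ncccn1` differs from compound 2 by pyrimidin-2-yl in place of benzoyl on an amine nitrogen. Going by the values given here, no measured pair shows this exchange, so nothing here gives its direction, and the expectation is taken as no step beyond the scatter, with a wide range. The estimate for compound 4 is 1800 nM, from 500 nM to 6500 nM, which is expected to mean a 1.0-fold lower number from compound 2 to compound 4 (0.01 log units; within the scatter).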

Compound 4, half-maximal inhibitory concentration: 1180 nM
Compound 4: the middle estimate sits 1.5-fold (0.18 log units) above what was measured; the range from low to high includes it.
By their numbers in this assay, from the lowest: compounds 3, 1, 4 and 2 (each within the scatter of the next, the first and the last beyond it).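

In this assay, pyrimidin-2-yl replaces benzoyl on the amine nitrogen with a 1.6-fold lower number from compound 2 to compound 4 (0.19 log units; within the scatter). At this position, then, the pair shows that the carbonyl of benzoyl can be lost, and the ring exchanged for one with two ring nitrogens, without a change beyond the scatter. No measurement here accounts for this result. The compounds shown leave open whether an amine or a carboxylic acid on the pyrimidin-2-yl ring would move the number beyond the scatter. They also leave open how pyridin-2-yl on the same amine nitrogen would compare.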